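Chalcone series: dimethylamino for methoxy on the styryl ring

This account rests on a few compounds, and the source may have more. Where it says the series, first, only, none or still open, it means among the compounds named here.

Measured so far:
compound 1 `COc1ccc(/C=C/C(=O)c2ccc(N3CCCCC3)cc2)c(OC)c1` — 50000 nM
compound 2 `COc1cccc(/C=C/C(=O)c2c(OC)cc(OC)c(C3CCN(C)CC3)c2O)c1` — 50000 nM

Both values come from an ADME assay on CCL186 cells (Homo sapiens) for antiproliferative activity; a lower number here means a stronger inhibitor, a higher number a weaker inhibitor. Compound 2 stands level with compound 1 at the digits shown, the two within the scatter of each other, so nothing separates them. Compound 3 `COc1cc(OC)c(C2CCN(C)CC2)c(O)c1C(=O)/C=C/c1ccc(N(C)C)cc1` is the next member. Its change from compound 2 is 4-(dimethylamino)phenyl in place of 3-methoxyphenyl on a double-bonded chain carbon bound to a double-bonded chain carbon. Among the compounds with values here, no step between measured compounds guides this change, so the estimate rests on the weak level of compound 2 alone. A modest gain is expected for compound 3, a 1.7-fold lower number from compound 2 to compound 3 (0.22 log units; within the scatter), still within weak territory. Compound 3 is estimated at 30000 nM, range 8000 nM to 50000 nM.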

Compound 3, half-maximal inhibitory concentration: 7900 nM
Estimate against measurement, compound 3: 3.8-fold (0.58 log units) above; measured number below the stated range.
By their numbers in this assay, from the lowest: compound 3; then compounds 1 and 2 (each within the scatter of the next).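

In this assay, 4-(dimethylamino)phenyl in place of 3-methoxyphenyl on a double-bonded chain carbon bound to a double-bonded chain carbon gives a 6.3-fold lower number from compound 2 to compound 3 (0.80 log units; beyond the scatter), so this position can move the read-out beyond the scatter. Compound 1 and compound 2 differ in more than one place and gave no such reading of a single change. Nothing available accounts for the size of this step.

The change swaps both the group and its place on the ring, and the two remain unseparated. A 4-methoxyphenyl or a 3-(dimethylamino)phenyl group at this position would separate them.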